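The source may report more compounds than this note shows. Statements on the series, on what has been measured and on what is new or still open speak of the compounds shown alone.

Measured in a physicochemical assay for solubility, measured as thermodynamic solubility, at pH 7.4; on this read-out higher numbers stand for higher solubility and lower numbers for lower solubility:
- compound 1 `O=C(O)Cn1nc(Cc2nc3cc(F)c(OCC4CC4)cc3[nH]2)c2ccccc2c1=O`: 841 ug/mL
- compound 2 `O=C(O)Cn1nc(Cn2cc3cc(OCC4CC4)c(Cl)cc3n2)c2ccccc2c1=O`: 334 ug/mL
- compound 3 `O=C(O)Cc1nn(Cc2cn3cc(OCC4CC4)c(Cl)cc3n2)c2ccccc2c1=O`: 919 ug/mL

Compound 3, at 919 ug/mL, cannot be told apart from compound 1, at 841 ug/mL, as the two values lie within the scatter of each other. The gap from compound 3 down to compound 2, at 334 ug/mL, is beyond the scatter.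

The next molecule is compound 4 `CCC(C(=O)O)c1nn(Cc2cn3cc(OCC4CC4)c(Cl)cc3n2)c2ccccc2c1=O`. Its change from compound 3 is ethyl in place of hydrogen on a saturated chain carbon bound to an aromatic carbon and a carbonyl carbon. Cut one bond further out, this reads as carboxymethyl to 1-carboxypropyl.

Within the data shown here, no pair of measured compounds differs in one place only, so the data offer no direct precedent and the expectation is a judgement. A moderate fall is expected, with an estimated 2.2-fold lower number from compound 3 to compound 4 (0.34 log units; beyond the scatter), only a little beyond the scatter. For compound 4 the expected value is 420 ug/mL, with an estimated range from 140 ug/mL to 950 ug/mL.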

Compound 4, solubility: 359 ug/mL
Estimate against measurement, compound 4: 1.2-fold (0.07 log units) above; low and high end bracket the measured number.
By their numbers in this assay, from the lowest: compounds 2 and 4 (each within the scatter of the next); then compounds 1 and 3 (each within the scatter of the next).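

In this assay, among these compounds, ethyl in place of hydrogen on a saturated chain carbon bound to an aromatic carbon and a carbonyl carbon gives a 2.6-fold lower number from compound 3 to compound 4 (0.41 log units; beyond the scatter), the only comparison here between compounds that differ in one place. It shows that this carbon is not a silent spot: the change from carboxymethyl to 1-carboxypropyl moves the number by a modest step, beyond the scatter, while compound 4 still gives 359 ug/mL. Nothing available here explains the fall.

With ethyl as the only group shown on this carbon, it remains open whether a smaller methyl, a longer propyl chain, a hydroxyl or an amine would give a smaller or larger step. Going by these compounds, it also remains open whether ethyl at the matching carbon would act the same way on the cores of compound 1 and compound 2.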